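This account rests on a few compounds, and the source may have more. Where it says the series, first, only, none or still open, it means among the compounds named here.

Measured compounds: compound 1 `C=C1[C@@H](OC(C)=O)C[C@@H]2[C@](C)(CO[Si](C)(C)C(C)(C)C)[C@H](OC(C)=O)CC[C@@]2(C)[C@@H]1C[C@@H](Nc1ccc(OC)cc1)C1=CCOC1=O` gives 5370 nM in a functional assay on HT-29 cells (Homo sapiens) for cytotoxicity, read by sulforhodamine B assay; a lower number here means a stronger inhibitor, a higher number a weaker inhibitor; compound 2 `C=C1[C@@H](OC(C)=O)C[C@@H]2[C@](C)(COC=O)[C@H](OC(C)=O)CC[C@@]2(C)[C@@H]1C[C@@H](Nc1ccc(OC)cc1)C1=CCOC1=O` gives 25400 nM; compound 3 `C=C1[C@@H](OC(C)=O)C[C@@H]2[C@](C)(CO[Si](C)(C)C(C)(C)C)[C@H](OC(C)=O)CC[C@@]2(C)[C@@H]1C/C=C1/C(=O)OC[C@H]1OC(C)=O` gives 4940 nM.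

Among these three numbers compound 1 stands second highest; against compound 3 it lies within the scatter, while compound 2 lies beyond it, the step being a 4.7-fold higher number from compound 1 to compound 2 (0.67 log units; beyond the scatter). Compound 4 `C=C1[C@@H](OC(C)=O)C[C@@H]2[C@](C)(CO[Si](C)(C)C(C)(C)C)[C@H](OC(C)=O)CC[C@@]2(C)[C@@H]1C[C@@H](Nc1ccc(Br)cc1)C1=CCOC1=O` is not yet measured. It differs from compound 1 by bromo in place of methoxy on an aromatic carbon. Going by the values given here, the one measured step concerns a change on an oxygen on a saturated carbon, a different place from the aromatic carbon changed here, so no measured step bears directly on the step to compound 4. With nothing to point either way, the expected step of a 1.1-fold lower number from compound 1 to compound 4 (0.03 log units; within the scatter) is none beyond the scatter. Compound 4 is therefore estimated at 5000 nM, in the range 1800 nM to 14000 nM.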

Compound 4, half-maximal inhibitory concentration: 4590 nM
For compound 4 the middle estimate is 1.1-fold (0.04 log units) above the measured one; low and high end bracket the measured number.
By their numbers in this assay, from the lowest: compounds 4, 3 and 1 (each within the scatter of the next); then compound 2.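

In this assay, bromo in place of methoxy on the aromatic carbon para to a large group gives a 1.2-fold lower number from compound 1 to compound 4 (0.07 log units; within the scatter), so the two groups cannot be told apart at this position. Going by these compounds alone, the earlier step concerned only a change on an oxygen on a saturated carbon, and this one adds a first reading on the aromatic ring. No evidence is available that bears on the reason for this result.

From the compounds shown here alone, whether an amine, a carboxylic acid or a nitrile on this carbon would read the same remains open. So does whether bromo would match methoxy on the core of compound 2.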